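A few compounds are considered here, and "the series" means these few. Any claim that something is new, unique, unknown or untested is made for them only; others in the source may bear on it.

Measured compounds in an ADME assay on Caco-2 cells (Homo sapiens) for permeability, in the apical to basolateral direction; on this read-out lower numbers stand for lower permeability and higher numbers for higher permeability:
compound 1 `Cn1cc(-c2nc3c(-c4ccc(CNC(=O)c5ccc(C(C)(C)C)cc5)c(F)c4)ccnc3[nH]2)cn1` gives 0.4 10^-6 cm/s;
compound 2 `Cn1cc(-c2nc3c(-c4ccc(CNC(=O)c5cc6c(s5)CCCC6)c(F)c4)ccnc3[nH]2)cn1` gives 0.6 10^-6 cm/s.

Among the compounds with values here, compound 2 stands beside compound 1, the only other number, and the two lie within the scatter of each other. Compound 3 `Cn1cc(-c2nc3c(-c4ccc(CNC(=O)c5ccc(C(C)(C)C)cn5)c(F)c4)ccnc3[nH]2)cn1` differs from compound 2 by a group of 10 heavy atoms (9 carbon, 1 nitrogen; one six-membered aromatic ring with 1 hetero atom) in place of a group of 9 heavy atoms (8 carbon, 1 sulfur; one five-membered aromatic ring with 1 hetero atom, one six-membered non-aromatic ring of carbon only), on a carbonyl carbon. One measured step on the same carbonyl carbon bears on this change: a 1.5-fold higher number from compound 1 to compound 2 (0.18 log units; within the scatter), a step within the scatter. Compound 3 carries a 5-(tert-butyl)pyridin-2-yl group, a six-membered aromatic ring with 1 hetero atom, where compound 1 carries a six-membered aromatic ring of carbon only. Compound 3 is therefore expected to stay within the scatter of compound 2, an expected step of a 1.2-fold lower number from compound 2 to compound 3 (0.08 log units; within the scatter). The estimate for compound 3 in this assay is 0.5 10^-6 cm/s, with a range from 0.2 10^-6 cm/s to 1.2 10^-6 cm/s.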

Compound 3, apparent permeability: 0.3 10^-6 cm/s
The estimate for compound 3 lay 1.7-fold (0.22 log units) above the measured number; measured number inside the range.
By their numbers in this assay, from the lowest: compounds 3, 1 and 2 (each within the scatter of the next).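

In this assay, 5-(tert-butyl)pyridin-2-yl in place of 4-(tert-butyl)phenyl on the carbonyl carbon (a 1.3-fold lower number from compound 1 to compound 3 (0.12 log units; within the scatter)) stays within the scatter, and so does the same group in place of the group carried by compound 2 (a 2.0-fold lower number from compound 2 to compound 3 (0.30 log units; within the scatter)). All three groups tried on this carbonyl carbon therefore lie within the scatter of one another, with a nitrogen or a sulfur in the aromatic ring or with carbon only. No measurement at hand explains these numbers. The compounds shown leave open whether an amine or a carboxylic acid on this aromatic ring would carry the number beyond the scatter.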